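Fluoro to trifluoromethyl swaps in an aryl-piperazine propanone series

The compounds below may be only part of what the source reports. "The series", "measured", "known", "first", "only" and "open" are said of these compounds alone.

Measured compounds and their values in an ADME assay on Vero cells (Chlorocebus sabaeus) for cytotoxicity, read by resazurin assay, with a stated time of 72 h; on this read-out higher numbers stand for weaker inhibition and lower numbers for stronger inhibition:
compound 1, `O=C(CCN1CCN(c2ccc(F)cc2)CC1)c1ccccc1`, 13400 nM
compound 2, `O=C(CCN1CCN(c2ccc(C(F)(F)F)cc2)CC1)c1ccccc1`, 15700 nM
compound 3, `O=C(CCN1CCN(c2ccc(F)cc2)CC1)c1ccc(C(F)(F)F)cc1`, 28500 nM

Compound 4, `O=C(CCN1CCN(c2ccc(C(F)(F)F)cc2)CC1)c1ccc(C(F)(F)F)cc1`, is not yet measured. It stands to compound 3 as compound 2 stands to compound 1. Between compound 1 and compound 2 the change is trifluoromethyl in place of fluoro on an aromatic carbon, and in this assay it made a 1.2-fold higher number from compound 1 to compound 2 (0.07 log units; within the scatter). The two cores differ by trifluoromethyl in place of hydrogen on an aromatic carbon, which gave a 2.1-fold higher number from compound 1 to compound 3 (0.33 log units; beyond the scatter). Compound 3 and compound 2 differ by a gap within the scatter, so no order between them is claimed. The change from compound 3 to compound 4 is trifluoromethyl in place of fluoro on an aromatic carbon; its place reads the same as in the first pair, so it is the same change, made twice in this set.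

With one prior instance, the expectation rests on that single step: the change from compound 3 to compound 4 is expected to make a 1.2-fold higher number from compound 3 to compound 4 (0.08 log units; within the scatter) in this assay, because compound 1 to compound 2 showed a 1.2-fold higher number from compound 1 to compound 2 (0.07 log units; within the scatter). Compound 4 is thus estimated at 34000 nM, between 17000 nM and 68000 nM.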

Compound 4, half-maximal inhibitory concentration: 49200 nM
Compound 4: the middle estimate sits 1.4-fold (0.16 log units) below what was measured, within the range that was stated.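

In this assay, 4-fluorophenyl to 4-(trifluoromethyl)phenyl on the second core gives a 1.7-fold higher number from compound 3 to compound 4 (0.24 log units; within the scatter), and the two instances of this change agree: the same change on two cores in this assay, a 1.2-fold higher number (0.07 log units; within the scatter) from compound 1 to compound 2 and a 1.7-fold higher number (0.24 log units; within the scatter) from compound 3 to compound 4, 1.5-fold (0.17 log units) apart, within the scatter of two such steps Trifluoromethyl in place of hydrogen on an aromatic carbon gives a 3.1-fold higher number from compound 2 to compound 4 (0.50 log units; beyond the scatter), and this change also carries from one core to the other: the same change on two cores in this assay, a 2.1-fold higher number (0.33 log units; beyond the scatter) from compound 1 to compound 3 and a 3.1-fold higher number (0.50 log units; beyond the scatter) from compound 2 to compound 4, 1.5-fold (0.17 log units) apart, within the scatter of two such steps This shows that both changes read alike across the two cores, but with only two instances of each, it does not show that they would carry to any further core, and the fluoro to trifluoromethyl steps, being within the scatter, establish no effect of that change on their own.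

Open is how a nitrile, a methoxy group or an amine would read at the same places, where the compounds shown carry only fluoro, trifluoromethyl or hydrogen. Also open, as far as these compounds go, is whether either change would carry over to a core with a longer chain between the carbonyl and the ring nitrogen.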